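The source may report more compounds than this note shows. Statements on the series, on what has been measured and on what is new or still open speak of the compounds shown alone.

In a functional assay on cells (Homo sapiens) for antiproliferative activity, read by MTT assay, with a stated time of 48 h (a higher number here means a weaker inhibitor, a lower number a stronger inhibitor), compound 1 `CCn1c(N)c(-c2nc3ccccc3[nH]2)c2nc(C#N)c(C#N)nc21` gives > 50000 nM as its result, and that value is a limit of the assay, not a number. Among the measured compounds shown here, compound 2 `CN1CCN(CCCn2c(N)c(-c3nc4ccccc4[nH]3)c3nc(C#N)c(C#N)nc32)CC1` reads 4520 nM in this assay and so holds the only true number so far. For the measured compounds named here, one measured step bears on what follows: it runs an at least 11-fold lower number from compound 1 to compound 2 (1.04 log units; beyond the scatter) when (4-methylpiperazin-1-yl)methyl takes the place of hydrogen, and it is large. Compound 3 `CCN(CC)CCCCn1c(N)c(-c2nc3ccccc3[nH]2)c2nc(C#N)c(C#N)nc21` alters that side chain, from 3-(4-methylpiperazin-1-yl)propyl to 4-(diethylamino)butyl, and the change counts as (diethylamino)methyl in place of 4-methylpiperazin-1-yl on a saturated chain carbon, three bonds along the chain from an aromatic nitrogen in full. Compound 3 still carries a side chain ending in an amino group, so the gain seen in the step of an at least 11-fold lower number from compound 1 to compound 2 (1.04 log units; beyond the scatter) is expected to stay largely intact. The expected change, a 1.3-fold higher number from compound 2 to compound 3 (0.12 log units; within the scatter) in this assay, is no clear step beyond the scatter. For compound 3 the estimated value is 6000 nM, with an expected range of 2000 nM to 20000 nM in this assay for now.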

Compound 3, half-maximal inhibitory concentration: 640 nM
Compound 3: middle estimate off by 9.4-fold (0.97 log units), on the high side; the whole stated range lies above it.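

In this assay, among the compounds shown here, the earlier compounds showed only that adding a chain ending in an amino group lowers the number, whereas compound 3 shows that the choice of chain also matters: exchanging 3-(4-methylpiperazin-1-yl)propyl for 4-(diethylamino)butyl gives a 7.1-fold lower number from compound 2 to compound 3 (0.85 log units; beyond the scatter). The whole gain for the chain ending in diethylamino now reads an at least 78-fold lower number from compound 1 to compound 3 (1.89 log units; beyond the scatter). That size is only a bound, and compound 1 is the one compound whose result is a limit and not a number: the limit of > 50000 nM in this assay, at which 1 of the 3 values shown sits.

This change alters both the chain length and the amine at its end, and the compounds shown cannot separate the two, which a 3-(diethylamino)propyl chain would begin to do. From the compounds shown here alone, how a morpholine ring or a carboxylic acid at the chain end would read also remains open.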